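The source may report more compounds than this note shows. Statements on the series, on what has been measured and on what is new or still open speak of the compounds shown alone.

Measured compounds:
compound 1, `O=C(Nn1c(-c2cccc([N+](=O)[O-])c2)nc2c(-c3ccc(F)cc3)n[nH]c2c1=O)c1cccnc1`, 24.9%
compound 2, `O=C(Nn1c(-c2cccc([N+](=O)[O-])c2)nc2c(-c3ccco3)n[nH]c2c1=O)c1cccnc1`, 1.66%
compound 3, `O=C(Nn1c(-c2cccc([N+](=O)[O-])c2)nc2c(-c3ccc(F)cc3)n[nH]c2c1=O)c1ccccc1`, 90.8%

All three were tested in a functional assay on DU-145 cells (Homo sapiens) for cytotoxicity, read by sulforhodamine B assay, with a stated time of 2 days, tested at 100 uM; a lower number here means less inhibition, a higher number more inhibition at the concentration tested (going by the name of the read-out). Compound 1 gives 24.9%, compound 2 gives 1.66%, and compound 3 gives 90.8%, the highest of the three, with both other compounds beyond the scatter from it.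

The change from compound 1 to compound 2 is furan-2-yl in place of 4-fluorophenyl on an aromatic carbon. Its step is a number 23.2 percentage points lower from compound 1 to compound 2 (beyond the scatter).

The cores of compound 1 and compound 3 differ by phenyl in place of pyridin-3-yl on a carbonyl carbon, and this step is a number 65.9 percentage points higher from compound 1 to compound 3 (beyond the scatter).

Compound 4, `O=C(Nn1c(-c2cccc([N+](=O)[O-])c2)nc2c(-c3ccco3)n[nH]c2c1=O)c1ccccc1`, is not yet measured in this assay. It differs from compound 3 by furan-2-yl in place of 4-fluorophenyl on an aromatic carbon, the same change as that from compound 1 to compound 2 with the same surroundings.

Among the compounds with values here, because the earlier step of a number 23.2 percentage points lower from compound 1 to compound 2 (beyond the scatter) is the only guide to this change, and it was measured from a starting point that was already low, its size on the high starting point of compound 3 is uncertain; a loss is expected, and the estimated step is a number 40.8 percentage points lower from compound 3 to compound 4 (beyond the scatter). Compound 4 is expected to reach about 50% in this assay, with a range of 15% to 85%, the middle of the range resting on compound 3 at 90.8% less a step of the kind seen before.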

Compound 4, a percentage reported as inhibition, at one concentration (the size of the read-out at that concentration, not a potency): 16.1%
For compound 4 the middle estimate is 33.9 percentage points above the measured one, and the stated range covers the measured number.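

In this assay, furan-2-yl in place of 4-fluorophenyl gives a number 74.7 percentage points lower from compound 3 to compound 4 (beyond the scatter), and phenyl in place of pyridin-3-yl gives a number 14.4 percentage points higher from compound 2 to compound 4 (beyond the scatter), so each change keeps its direction on the second core but not its size. A fixed step size for the furan-2-yl change therefore does not hold in this series: the same change on two cores in this assay, a number 23.2 percentage points lower (beyond the scatter) from compound 1 to compound 2 and a number 74.7 percentage points lower (beyond the scatter) from compound 3 to compound 4, 51.5 percentage points apart, beyond the scatter of two such steps The phenyl change fails in the same way, which shows that the effects at the two places do not simply add up across these four compounds, but it does not show why, nor how either change would behave on any other core: the same change on two cores in this assay, a number 65.9 percentage points higher (beyond the scatter) from compound 1 to compound 3 and a number 14.4 percentage points higher (beyond the scatter) from compound 2 to compound 4, 51.5 percentage points apart, beyond the scatter of two such steps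

The compounds shown leave open whether the high value of compound 3, 90.8%, depends on the pairing of phenyl with 4-fluorophenyl or would persist with other groups, such as a thiophene ring or a short alkyl chain on the aromatic carbon, or a phenyl ring carrying an amine or a carboxylic acid on the carbonyl carbon. Also open, as far as these compounds go, is whether the same pattern would appear at lower concentrations or in other cell lines.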